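This account rests on a few compounds, and the source may have more. Where it says the series, first, only, none or still open, it means among the compounds named here.

Measured in a functional assay on MDA-MB-231 cells (Homo sapiens) for cytotoxicity; on this read-out higher numbers stand for weaker inhibition and lower numbers for stronger inhibition:
- compound 1 `C[C@@H]1O[C@@H](n2c3ccccc3c3c4c(c5c6ccccc6ccc5c32)C(=O)NC4=O)[C@H](O)[C@H](O)[C@H]1O` gives 4700 nM
- compound 2 `O=C1NC(=O)c2c1c1c3ccccc3ccc1c1c2c2ccccc2n1[C@H]1OC[C@@H](O)[C@@H](O)[C@H]1O` gives 3300 nM

Compound 2 at 3300 nM stands within the scatter of compound 1, so this assay does not separate these two compounds.

The next compound is compound 3 `O=C1NC(=O)c2c1c1c3ccccc3ccc1c1c2c2ccccc2n1[C@@H]1O[C@H](CO)[C@@H](O)[C@H](O)[C@H]1O`, which keeps the core of compound 2 and differs only in the group on the aromatic nitrogen. The change is a group of 11 heavy atoms (6 carbon, 5 oxygen; one six-membered non-aromatic ring with 1 hetero atom) in place of a group of 9 heavy atoms (5 carbon, 4 oxygen; one six-membered non-aromatic ring with 1 hetero atom), on an aromatic nitrogen and the group that enters is 3,4,5-trihydroxy-6-(hydroxymethyl)oxan-2-yl. Going by the values given here, one measured step bears on this change, and it too replaces one group holding a six-membered non-aromatic ring with another at that aromatic nitrogen. That step is a 1.4-fold lower number from compound 1 to compound 2 (0.15 log units; within the scatter) and it stays within the scatter. Among the compounds with values here, it is only a single step, so it gives limited guidance, but on this evidence no shift beyond the scatter is expected in this assay for the new group.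

The expected change is small, an estimated 1.1-fold higher number from compound 2 to compound 3 (0.03 log units; within the scatter) and no more than that. For compound 3 the estimated value is 3500 nM with an expected range from 1200 nM to 10000 nM in a repeat measurement.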

Compound 3, half-maximal inhibitory concentration: 2700 nM
For compound 3 the middle estimate is 1.3-fold (0.11 log units) above the measured one; the range from low to high includes it.
By their numbers in this assay, from the lowest: compounds 3, 2 and 1 (each within the scatter of the next).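

In this assay, placing 3,4,5-trihydroxy-6-(hydroxymethyl)oxan-2-yl on the aromatic nitrogen gives a 1.2-fold lower number from compound 2 to compound 3 (0.09 log units; within the scatter), and the direct exchange for 3,4,5-trihydroxy-6-methyloxan-2-yl, which amounts to a hydroxymethyl group in place of a methyl group on that ring, gives a 1.7-fold lower number from compound 1 to compound 3 (0.24 log units; within the scatter). Going by these compounds alone, the single earlier step covered only one pair of groups, whereas all three pairs among compound 1, compound 2 and compound 3 now stay within the scatter, so this assay separates none of these three groups at this position. Nothing measured here offers an explanation for these values.

The compounds shown leave open whether a group lacking the six-membered non-aromatic ring, such as a longer chain bearing an amine, would shift the number beyond the scatter when placed on the aromatic nitrogen, and whether a carboxylic acid in place of the hydroxymethyl group would do so. They also leave open whether a methyl group in place of the amide hydrogen on the shared core would change the reading in this assay.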